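Chloroacetamide in place of the glycinamide on a coumarin core

The compounds below may be only part of what the source reports. "The series", "measured", "known", "first", "only" and "open" are said of these compounds alone.

Compounds measured so far:
compound 1, `O=c1cc(CCO)c2ccc(OCc3cccc(Cl)c3)cc2o1`, 4680 nM
compound 2, `NC(=O)CCc1cc(=O)oc2cc(OCc3cccc(Cl)c3)ccc12`, 4270 nM
compound 3, `NC(=O)CNc1cc(=O)oc2cc(OCc3cccc(Cl)c3)ccc12`, 95.5 nM

In an assay on brain (strain Sprague-Dawley) for inhibition of Amine oxidase [flavin-containing] A (Rattus norvegicus), read by spectrophotometry (on this read-out higher numbers stand for weaker inhibition and lower numbers for stronger inhibition), compound 3 stands lowest of the three measured compounds, and both of its neighbours lie well apart: a 45-fold lower number from compound 2 to compound 3 (1.65 log units; beyond the scatter) and a 49-fold lower number from compound 1 to compound 3 (1.69 log units; beyond the scatter). By contrast a 1.1-fold lower number from compound 1 to compound 2 (0.04 log units; within the scatter), so swapping a hydroxy for a carbamoyl on the chain left the number unchanged.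

Compound 4, `O=C(CCl)Nc1cc(=O)oc2cc(OCc3cccc(Cl)c3)ccc12`, has not yet been measured. It differs from compound 3 as follows: (chloromethyl)carbonyl in place of carbamoylmethyl on a nitrogen on an aromatic ring. Among the compounds with values here, no measured step covers this exact change; the steps that bear on it show that the large gain appeared when the group on the aromatic carbon became the (carbamoylmethyl)amino group, while altering the end of a carbon chain did nothing beyond the scatter. Compound 4 keeps the nitrogen on the ring but loses the donor of the carbamoyl, so some loss is expected, of moderate size: a 3.1-fold higher number from compound 3 to compound 4 (0.50 log units; beyond the scatter). The estimate for compound 4 in this assay is 300 nM, with a range from 60 nM to 1500 nM.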

Compound 4, half-maximal inhibitory concentration: 5750 nM
Compound 4: middle estimate off by 19-fold (1.28 log units), on the low side; measured number above the stated range.
By their numbers in this assay, from the lowest: compound 3; then compounds 2, 1 and 4 (each within the scatter of the next).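

In this assay, keeping a nitrogen on the aromatic ring did not by itself preserve the low number: a 60-fold higher number from compound 3 to compound 4 (1.78 log units; beyond the scatter). The gain therefore belongs to the (carbamoylmethyl)amino group as a whole and not to the ring nitrogen alone, and with ((chloromethyl)carbonyl)amino on that aromatic carbon the compound stands with the two chain compounds: a 1.3-fold higher number from compound 2 to compound 4 (0.13 log units; within the scatter), and a 1.2-fold higher number from compound 1 to compound 4 (0.09 log units; within the scatter). Nothing measured here offers an explanation for this loss.

The compounds shown leave open whether the low number depends on the terminal carbamoyl or on the nitrogen carrying no carbonyl, since the change from compound 3 to compound 4 alters both at once. A plain amine, an acetyl group on that nitrogen, or a carboxylic acid in place of the carbamoyl could separate these.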